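Two aryloxyacetamide thiazoles and a matched pair to close

The compounds below may be only part of what the source reports. "The series", "measured", "known", "first", "only" and "open" are said of these compounds alone.

The series is measured in a functional assay on MDA-MB-468 cells (Homo sapiens) for cytotoxicity, read by MTT assay, with a stated time of 48 h; on this read-out lower numbers stand for stronger inhibition and higher numbers for weaker inhibition. Compound 1 `Cc1ccccc1OCC(=O)Nc1nc(-c2ccc(Br)cc2)cs1` gives 44900 nM. Compound 2 `O=C(COc1ccc(F)cc1F)Nc1nc(-c2ccc(Br)cc2)cs1` gives 44200 nM. Compound 3 `Cc1ccccc1OCC(=O)Nc1nc(-c2ccc(Cl)cc2)cs1` gives 40100 nM. Compound 4 `O=C(COc1ccc(F)cc1F)Nc1nc(-c2ccc(Cl)cc2)cs1` has not yet been measured.

Compound 2 differs from compound 1 by 2,4-difluorophenyl in place of 2-methylphenyl on an oxygen on a saturated carbon, and the step is a 1.0-fold lower number from compound 1 to compound 2 (0.01 log units; within the scatter). Compound 3 differs from compound 1 by chloro in place of bromo on an aromatic carbon, with a step of a 1.1-fold lower number from compound 1 to compound 3 (0.05 log units; within the scatter). All three measured values sit within the scatter of one another, so no order among them is claimed.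

Compound 4 differs from compound 3 by 2,4-difluorophenyl in place of 2-methylphenyl on an oxygen on a saturated carbon. This is the same change as that from compound 1 to compound 2, made on the core of compound 3 instead of the core of compound 1; the two cores differ by chloro in place of bromo on an aromatic carbon. The place of the change is worded identically in both pairs, so it is treated as the same change. Among the compounds here it occurs twice in all.

For compound 4, the expected step in this assay is a 1.0-fold lower number from compound 3 to compound 4 (0.00 log units; within the scatter), resting on the earlier step of a 1.0-fold lower number from compound 1 to compound 2 (0.01 log units; within the scatter), which was within the scatter. It also rests on the value of compound 3, which in this assay gives 40100 nM. Compound 4 is therefore estimated at 40000 nM, with an expected range from 20000 nM to 80000 nM.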

Compound 4, half-maximal inhibitory concentration: 32900 nM
For compound 4 the middle estimate is 1.2-fold (0.08 log units) above the measured one; the range from low to high includes it.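

In this assay, 2,4-difluorophenyl in place of 2-methylphenyl on the chloro-bearing core gives a 1.2-fold lower number from compound 3 to compound 4 (0.09 log units; within the scatter), and this agrees with the same change on the bromo-bearing core: the same change on two cores in this assay, a 1.0-fold lower number (0.01 log units; within the scatter) from compound 1 to compound 2 and a 1.2-fold lower number (0.09 log units; within the scatter) from compound 3 to compound 4, 1.2-fold (0.08 log units) apart, within the scatter of two such steps. Chloro in place of bromo, with 2,4-difluorophenyl present, gives a 1.3-fold lower number from compound 2 to compound 4 (0.13 log units; within the scatter), and this also agrees with the same change made with 2-methylphenyl present: the same change on two cores in this assay, a 1.1-fold lower number (0.05 log units; within the scatter) from compound 1 to compound 3 and a 1.3-fold lower number (0.13 log units; within the scatter) from compound 2 to compound 4, 1.2-fold (0.08 log units) apart, within the scatter of two such steps. Both changes therefore carry from one core to the other without a detectable difference, but every step here lies within the scatter, so this is agreement between steps too small to read and does not show that a step of real size would carry over in the same way, nor does it set any order among the four compounds.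

Still open, on these data alone, is whether any change gives a step beyond the scatter, for example an amine or a carboxylic acid in place of the aryl group on the oxygen, or a longer chain in place of the saturated carbon. Only such a step, made on both cores, would put the carrying over of a change in this series to a real test.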